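A few compounds are considered here, and "the series" means these few. Any claim that something is new, unique, unknown or untested is made for them only; others in the source may bear on it.

Of the compounds shown here, three built on the shared core have been measured so far in a functional assay, with a stated time of 6 min (a higher number here means a weaker inhibitor, a lower number a stronger inhibitor), for this series. Compound 1 `COc1ccc(NCn2nc(-c3ccc4c(c3)OCCO4)oc2=S)cc1` gives 5830 nM and compound 2 `CCOc1ccccc1NCn1nc(-c2ccc3c(c2)OCCO3)oc1=S` gives 5280 nM while compound 3 `O=[N+]([O-])c1ccccc1NCn1nc(-c2ccc3c(c2)OCCO3)oc1=S` gives 10900 nM as the highest of the three numbers. The two gaps up to it are a 1.9-fold higher number from compound 1 to compound 3 (0.27 log units; within the scatter) and a 2.1-fold higher number from compound 2 to compound 3 (0.31 log units; beyond the scatter) in this small set.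

Compound 4 `Cc1ccc(NCn2nc(-c3ccc4c(c3)OCCO4)oc2=S)cc1` is still unmeasured. It differs from compound 3 on an amine nitrogen, where 4-methylphenyl stands in place of 2-nitrophenyl (4-methylphenyl in place of 2-nitrophenyl on an amine nitrogen). Within the data shown here, no measured compound carries 4-methylphenyl, so the closest guide is compound 1 at 5830 nM with its 4-methoxyphenyl. Changing that group for 2-ethoxyphenyl moved little, with a 1.1-fold lower number from compound 1 to compound 2 (0.04 log units; within the scatter) as the evidence. Read backwards, the two steps up to compound 3 point to a small move toward a lower number, near the edge of the scatter. The estimated change is a 1.7-fold lower number from compound 3 to compound 4 (0.24 log units; within the scatter) in this assay here. For compound 4 the estimated value is 6300 nM with an expected range from 2800 nM to 13000 nM in this assay when tested.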

Compound 4, half-maximal inhibitory concentration: 5700 nM
Estimate against measurement, compound 4: 1.1-fold (0.04 log units) above, and the stated range covers the measured number.
By their numbers in this assay, from the lowest: compounds 2, 4, 1 and 3 (each within the scatter of the next, the first and the last beyond it).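

In this assay, among these compounds, methyl in place of methoxy on an aromatic carbon comes out as a 1.0-fold lower number from compound 1 to compound 4 (0.01 log units; within the scatter), so this is the first one-place swap on that ring with no visible effect on the reading. The 4-methylphenyl group, which has no hydrogen-bond acceptors, also matches 2-ethoxyphenyl on the amine nitrogen, at a 1.1-fold higher number from compound 2 to compound 4 (0.03 log units; within the scatter), and replacing 2-nitrophenyl gives a 1.9-fold lower number from compound 3 to compound 4 (0.28 log units; within the scatter), which is also within the scatter. The only step beyond the scatter therefore remains the one between compound 2 and compound 3, and nothing shown explains why these groups read so alike.

Still open, from the compounds shown here alone, is how a plain unsubstituted phenyl would read on the amine nitrogen. Also open, going by these compounds, is whether a carboxylic acid or an amine on that ring would shift the number beyond the scatter.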